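Swapping 3-methoxyphenyl for 4-methoxyphenyl: notes on compound 4

The compounds below may be only part of what the source reports. "The series", "measured", "known", "first", "only" and "open" are said of these compounds alone.

In a functional assay on A-375 cells (Homo sapiens) for antiproliferative activity, read by MTT assay, with a stated time of 72 h (on this read-out lower numbers stand for stronger inhibition and higher numbers for weaker inhibition), compound 1 (`COc1cccc(N2C(=O)COc3ccc(-c4cnc(Cl)c(NS(=O)(=O)c5ccc(F)cc5)c4)cc32)c1`) gives > 40000 nM, which is a limit of the assay and not a number. Compound 3 (`COc1ccc(N2C(=O)COc3ccc(-c4ccc(O)cc4)cc32)cc1`) gives > 40000 nM, also a limit. Compound 2 (`O=C1COc2ccc(-c3cccc(NS(=O)(=O)c4ccc(F)cc4)c3)cc2N1`) is the only one of these with a measured number, 20100 nM. Compound 1 therefore stands at the limit of > 40000 nM in this assay, at which 2 of the 3 values shown sit.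

Compound 4 (`COc1ccc(N2C(=O)COc3ccc(-c4cnc(Cl)c(NS(=O)(=O)c5ccc(F)cc5)c4)cc32)cc1`) has the same atoms as compound 1, with 4-methoxyphenyl in place of 3-methoxyphenyl on an amide-type nitrogen in a ring. For the measured compounds named here, no pair of measured compounds shows what this change does, and compound 1 offers only a limit as a starting point. In this assay, no step beyond the scatter is therefore expected, and no direction is favoured. The expected outcome is a number no higher from compound 1 to compound 4 (the limit leaves the size open). Compound 4 is estimated at 40000 nM, with an expected range from 12000 nM to 60000 nM, and a report of a limit alone is the more likely result.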

Compound 4, half-maximal inhibitory concentration: 32700 nM
Estimate against measurement, compound 4: 1.2-fold (0.09 log units) above; the range from low to high includes it.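

In this assay, for the compounds shown here, 4-methoxyphenyl in place of 3-methoxyphenyl on the amide-type nitrogen in a ring gives an at least 1.2-fold lower number from compound 1 to compound 4 (0.08 log units; that floor lies within the scatter), the first step that can be read at this position. Compound 4 gives 32700 nM, a measured number for a methoxyphenyl group at this position. Compound 1 gives > 40000 nM, which is a limit of the assay and not a number, and such limits remain frequent in this set: the limit of > 40000 nM in this assay, at which 2 of the 4 values shown sit.

Whether moving the methoxy group changes anything cannot be told from a floor that lies within the scatter, and the full size of the step stays unread. The compounds shown also leave open what an amine or a carboxylic acid on this phenyl ring, or a longer chain in place of the methoxy group, would do in this assay.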